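The source may report more compounds than this note shows. Statements on the series, on what has been measured and on what is new or still open speak of the compounds shown alone.

Two compounds have numbers in a functional assay on L02 cells (Homo sapiens) for inhibition, read by Griess assay, with stated times of 1 h and 24 h; a higher number here means a weaker inhibitor, a lower number a stronger inhibitor. Compound 1 `CCCc1nn(C)c2c(NC3CC3)nc(/C=C/c3nc(C)c(C)nc3C)nc12` gives 706000 nM, and compound 2 `COc1cc(/C=C/c2nc(N3CCCC3)c3sccc3n2)cc(OC)c1OC` gives 681000 nM; the two values lie within the scatter of each other, so compound 2 stands alongside compound 1 with nothing to separate them. For the measured compounds named here, compound 3 `COc1cc(/C=C/c2nc(N(C)c3ccccc3)c3sccc3n2)cc(OC)c1OC` carries methyl(phenyl)amino in place of pyrrolidin-1-yl on an aromatic carbon, and no other pair of measured compounds shows a change of this kind. With nothing in the two numbers pointing in either direction, the expected step from compound 2 to compound 3 in this assay is a 1.0-fold lower number from compound 2 to compound 3 (0.02 log units; within the scatter), none beyond the scatter. Compound 3 is therefore estimated at 650000 nM, within a range from 250000 nM to 1600000 nM.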

Compound 3, half-maximal inhibitory concentration: 767000 nM
Beside the measured number, compound 3's estimate is 1.2-fold (0.07 log units) below it; the measured number falls inside the stated range.
By their numbers in this assay, from the lowest: compounds 2, 1 and 3 (each within the scatter of the next).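

Replacing pyrrolidin-1-yl with methyl(phenyl)amino on the aromatic carbon next to the ring nitrogen gives, in this assay, a 1.1-fold higher number from compound 2 to compound 3 (0.05 log units; within the scatter). This single comparison shows that, on this core, the swap to a group with more heavy atoms and a six-membered aromatic ring leaves the number within the scatter. No measurement at hand speaks to why the two values sit so close. Going by these compounds, whether a primary amine or a carboxylic acid at this position would move the number remains open. So does whether the same swap would behave alike on a different core.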